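Compound 1 to compound 4: exchanging one aromatic ring

This account rests on a few compounds, and the source may have more. Where it says the series, first, only, none or still open, it means among the compounds named here.

In a physicochemical assay for lipophilicity (on this read-out higher numbers stand for higher lipophilicity and lower numbers for lower lipophilicity), compound 1 `Cc1nc(-c2cc(C(F)(F)F)ccc2[C@@H]2CCOc3cc(S(=O)(=O)Nc4nccs4)ccc32)co1` gives 2.9. Compound 2 `Cc1nc(-c2cc(C(F)(F)F)ccc2[C@H]2CCOc3cc(S(=O)(=O)Nc4nccs4)ccc32)co1` gives 2.9 and compound 3 `Cc1ccc(-c2cc(C(F)(F)F)ccc2[C@H]2CCOc3cc(S(=O)(=O)Nc4ccncn4)ccc32)cn1` gives 3, so all three lie within the usual scatter of one another. Going by the values given here, the only measured step shows no change at the digits printed from compound 1 to compound 2 (within the scatter). It concerns (the fact that compounds 1 and 2 differ only in the configuration as drawn), so it offers no guide to exchanging a group.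

The not yet measured compound 4 `O=S(=O)(Nc1nccs1)c1ccc2c(c1)OCC[C@H]2c1ccc(C(F)(F)F)cc1-c1ccc(F)cc1` carries a different group: 4-fluorophenyl in place of 2-methyl-1,3-oxazol-4-yl on an aromatic carbon. A six-membered aromatic ring of carbon only, the 4-fluorophenyl, replaces the five-membered aromatic ring with hetero atoms, the 2-methyl-1,3-oxazol-4-yl. The place is on an aromatic carbon, ortho to a large group and meta to a trifluoromethyl group.

Among the compounds with values here, no measured step covers such an exchange, so the expectation rests on the structural change alone, starting from compound 1 at 2.9. A rise beyond the scatter in this assay is expected, and the estimated step is a number 0.90 log units higher from compound 1 to compound 4 (beyond the scatter). Compound 4 is estimated at 3.8, with an expected range from 3.2 to 4.4.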

Compound 4, distribution coefficient: 4.5
For compound 4 the middle estimate is 0.70 log units below the measured one; the whole stated range lies below it.
By their numbers in this assay, from the lowest: compounds 1, 2 and 3 (each within the scatter of the next); then compound 4.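

In this assay, placing 4-fluorophenyl in place of 2-methyl-1,3-oxazol-4-yl gives a number 1.60 log units higher from compound 1 to compound 4 (beyond the scatter) at this place, on an aromatic carbon ortho to a large group and meta to a trifluoromethyl group. Going by these compounds alone, the only earlier step, no change at the digits printed from compound 1 to compound 2 (within the scatter), was a change of configuration, so this is the first sign that exchanging the group on this aromatic carbon can move the read-out, and by a large amount. Nothing measured here on these two groups accounts for the size of the step.

Going by these compounds, it remains open whether the step belongs to the fluorine, to the carbon-only six-membered ring or to the loss of the hetero atoms, which an unsubstituted phenyl group at this place would help to separate. On these data alone, how an amine or a carboxylic acid on this carbon would read in this assay also remains open.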